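Methoxy to ethoxy: compound 2 to compound 3

The source may report more compounds than this note shows. Statements on the series, on what has been measured and on what is new or still open speak of the compounds shown alone.

Values in a functional assay on K562 cells (Homo sapiens) for antiproliferative activity, read by MTT assay, with a stated time of 72 h; a lower number here means a stronger inhibitor, a higher number a weaker inhibitor:
- compound 1 `COc1ccc(-c2ncnn2-c2cc(OC)c(OC)c(OC)c2)cc1`: 950 nM
- compound 2 `COc1cccc(-c2ncnn2-c2cc(OC)c(OC)c(OC)c2)c1`: > 10000 nM (a limit, not a number)

Compound 2 has no number on the scale and stands at the limit of > 10000 nM in this assay, at which 1 of the 2 values shown sits. Compound 3 `CCOc1cccc(-c2ncnn2-c2cc(OC)c(OC)c(OC)c2)c1` keeps the methoxy place of compound 2 and turns methoxy into ethoxy: methyl in place of hydrogen on a saturated chain carbon bound to an oxygen on an aromatic ring.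

Among the compounds with values here, only one measured step bears on this, and only indirectly. It is an at least 10-fold higher number from compound 1 to compound 2 (1.02 log units; beyond the scatter), large and beyond the scatter, with 3-methoxyphenyl in place of 4-methoxyphenyl on an aromatic carbon. Within the data shown here, no measured step covers a methoxy to ethoxy change, so its size is an expectation with little support. Among the measured compounds shown here, with an at least 10-fold higher number from compound 1 to compound 2 (1.02 log units; beyond the scatter) as the only guide, no return towards compound 1 is expected, and a result reported again as a limit is likely. The expected change is a step that the limit leaves unreadable from compound 2 to compound 3, with none expected beyond the scatter. For compound 3 the estimate in this assay is 14000 nM, with an expected range of 4000 nM to 40000 nM.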

Compound 3, half-maximal inhibitory concentration: > 10000 nM
Compound 3: a limit, no number (the forecaster's own chance of this, stated with the estimate: 75%); the middle value lies beyond the limit too.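

No step from compound 2 to compound 3 can be read in this assay, because both compounds give a limit and not a number: the limit of > 10000 nM in this assay, at which 2 of the 3 values shown sit.

The compounds shown leave open whether methoxy to ethoxy changes the value in this assay at all, and what that change does on a compound with a readable number, such as compound 1.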